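Phenyl for pyridin-4-yl on the shared core

A few compounds are considered here, and "the series" means these few. Any claim that something is new, unique, unknown or untested is made for them only; others in the source may bear on it.

Measured compounds:
- compound 1 `Oc1cccc(-c2cc(-c3ccncc3)nc(-c3ccccc3Cl)c2)c1`: "not determined" (no result reported)
- compound 2 `Oc1cccc(-c2cc(-c3ccc(Cl)cc3)nc(-c3cccnc3)c2)c1`: 16800 nM
- compound 3 `Oc1ccc(-c2cc(-c3cccc(Cl)c3)nc(-c3ccco3)c2)cc1`: 8020 nM

Compound 1 carries a pyridin-4-yl group, a 2-chlorophenyl group and a 3-hydroxyphenyl group on the shared core. In a functional assay on HCT-15 cells (Homo sapiens) for cytotoxicity, read by CCK-8 assay and cell counting, with a stated time of 2 days (a higher number here means a weaker inhibitor, a lower number a stronger inhibitor), compound 1 is reported as "not determined" (no result reported), so it stands on no number of its own. The series around it is weak: in this assay compound 2 gives 16800 nM, and compound 3 gives 8020 nM. Among the compounds with values here, no step between two measured compounds that differ in one place is available, and the two values of compound 2 and compound 3 differ in more than one group, so they show only the range in which this core has so far landed.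

Compound 4 `Oc1cccc(-c2cc(-c3ccccc3)nc(-c3ccccc3Cl)c2)c1` is the unmeasured partner of compound 1. The change is phenyl in place of pyridin-4-yl on an aromatic carbon. Because compound 1 has no value, the step to compound 4 cannot be anchored; the expectation rests only on compound 2 and compound 3, both weak in this assay. A change of this size is expected to move the read-out by no more than the usual scatter in either direction, if the starting point resembles these two.

Compound 4 is therefore estimated at 12000 nM in this assay, within 3000 nM to 50000 nM.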

Compound 4, half-maximal inhibitory concentration: 2930 nM
Estimate against measurement, compound 4: 4.1-fold (0.61 log units) above; the measured number lies below the stated range.
By their numbers in this assay, from the lowest: compound 4; then compound 3; then compound 2.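

In this assay compound 4 gives 2930 nM and compound 1 stands at "not determined" (no result reported) with no number, so no step can be read between them, and compound 2 and compound 3 differ from compound 4 in more than one place. No measured evidence bears on this result. The compounds shown leave open what phenyl in place of pyridin-4-yl does to the read-out on the shared core.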